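The compounds below may be only part of what the source reports. "The series", "measured", "known", "first", "only" and "open" are said of these compounds alone.

Three compounds sharing one core have been measured in a physicochemical assay for lipophilicity, using the shake flask method, in phosphate buffer, measured as octanol-water partition, at pH 7.4; a higher number here means a more lipophilic compound, a lower number a more polar compound:

compound 1, `COc1cc(-c2cc(C(=O)O)c3ccccc3n2)ccc1OCC(=O)Nc1cccc(C)c1`, gives 1.5;
compound 2, `COc1cc(-c2cc(C(=O)O)c3ccccc3n2)ccc1OCC(=O)NCc1ccco1`, gives -0.3;
compound 3, `COc1cc(-c2cc(C(=O)O)c3ccccc3n2)ccc1OCC(=O)NCc1cccs1`, gives 0.

Compound 3 stands second highest of the three numbers. Its nearest neighbour is compound 2, and that gap, a number 0.30 log units higher from compound 2 to compound 3 (within the scatter), lies within the scatter, while the gap to compound 1, a number 1.50 log units lower from compound 1 to compound 3 (beyond the scatter), lies beyond it. The next compound, compound 4, `COc1cc(-c2cc(C(=O)O)c3ccccc3n2)ccc1OCC(=O)NC1CCCCC1`, differs from compound 3 in one place: cyclohexyl in place of (thiophen-2-yl)methyl on an amide-type nitrogen. Among the measured compounds shown here, none of the measured steps makes this exact change. The two large steps, a number 1.80 log units lower from compound 1 to compound 2 (beyond the scatter) and a number 1.50 log units lower from compound 1 to compound 3 (beyond the scatter), both replace 3-methylphenyl on the amide nitrogen with a five-membered ring on a methylene, and the small step, a number 0.30 log units higher from compound 2 to compound 3 (within the scatter), swaps one such ring for another; so the measured data show only how widely changes at this nitrogen can move the number, not the direction of this particular one. For compound 4 the expectation is a moderate rise, a number 0.70 log units higher from compound 3 to compound 4 (beyond the scatter), giving an estimate of 0.7, within 0.1 to 1.3.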

Compound 4, distribution coefficient: 0.8
Compound 4: middle estimate off by 0.10 log units, on the low side; measured number inside the range.
By their numbers in this assay, from the lowest: compounds 2 and 3 (each within the scatter of the next); then compound 4; then compound 1.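

In this assay, among the compounds shown here, cyclohexyl on the amide-type nitrogen gives the first measured change at this position that starts from a five-membered ring on a methylene and clearly raises the number, both for (thiophen-2-yl)methyl (a number 0.80 log units higher from compound 3 to compound 4 (beyond the scatter)) and for (furan-2-yl)methyl (a number 1.10 log units higher from compound 2 to compound 4 (beyond the scatter)). The (thiophen-2-yl)methyl and cyclohexyl groups both have 6 heavy atoms, so the number at this nitrogen can shift with no change in that count. Cyclohexyl still does not reach 3-methylphenyl (a number 0.70 log units lower from compound 1 to compound 4 (beyond the scatter)), which places it between the two kinds of group already seen here.

Going by these compounds, this change alters the ring and removes the methylene in one step, so the share of each remains open; cyclohexylmethyl or benzyl on the same nitrogen would help separate them. Nothing shown here explains why the number moves.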